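Swapping fluoro for chloro on the amide-linked ring

The source may report more compounds than this note shows. Statements on the series, on what has been measured and on what is new or still open speak of the compounds shown alone.

Three compounds have been measured in a physicochemical assay for lipophilicity, using the shake flask method, in phosphate buffer, measured as octanol-water partition, at pH 7.4; a higher number here means a more lipophilic compound, a lower number a more polar compound:
compound 1 `COc1cc(-c2cc(C(=O)O)c3ccccc3n2)ccc1OCC(=O)Nc1ccccc1C` gives 0.8;
compound 2 `COc1cc(-c2cc(C(=O)O)c3ccccc3n2)ccc1OCC(=O)Nc1cccc(F)c1` gives 1.6;
compound 3 `COc1cc(-c2cc(C(=O)O)c3ccccc3n2)ccc1OCC(=O)Nc1ccc(F)cc1` gives 1.1.

Compound 3 holds the second highest of these three numbers. The step of a number 0.30 log units higher from compound 1 to compound 3 (within the scatter) lies within the scatter, so no order between those two can be claimed, whereas the step of a number 0.50 log units lower from compound 2 to compound 3 (beyond the scatter) lies beyond it. Compound 4 `COc1cc(-c2cc(C(=O)O)c3ccccc3n2)ccc1OCC(=O)Nc1ccc(Cl)cc1` differs from compound 3 by chloro in place of fluoro on an aromatic carbon. Among the compounds with values here, none of the measured steps, a number 0.80 log units higher from compound 1 to compound 2 (beyond the scatter), a number 0.30 log units higher from compound 1 to compound 3 (within the scatter) or a number 0.50 log units lower from compound 2 to compound 3 (beyond the scatter), exchanges one halogen for another at the same place, so they do not bear directly on this change; the expectation rests on the change itself. A modest rise is expected, a number 0.50 log units higher from compound 3 to compound 4 (beyond the scatter). Compound 4 is therefore estimated at 1.6, with a range from 1.1 to 2.1.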

Compound 4, distribution coefficient: 1.5
The estimate for compound 4 lay 0.10 log units above the measured number; the range from low to high includes it.
By their numbers in this assay, from the lowest: compounds 1 and 3 (each within the scatter of the next); then compounds 4 and 2 (each within the scatter of the next).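

In this assay, within the data shown here, chloro in place of fluoro on an aromatic carbon para to a large group gives a number 0.40 log units higher from compound 3 to compound 4 (beyond the scatter) as the first exchange of one halogen for another at one place. The new compound also shows a number 0.70 log units higher from compound 1 to compound 4 (beyond the scatter) and a number 0.10 log units lower from compound 2 to compound 4 (within the scatter) so that no order can be claimed for that last pair. Nothing measured here explains the halogen step. Still open, as far as these compounds go, is how bromo or a nitrile would read at this place, and whether the same exchange on the 3-fluorophenyl ring gives a similar step.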